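The source may report more compounds than this note shows. Statements on the series, on what has been measured and on what is new or still open speak of the compounds shown alone.

This piece concerns an ADME assay on cells (Macrophage, Mus musculus) for cytotoxicity (a lower number here means that less compound is tolerated, a higher number that more compound is tolerated), in which three compounds have been measured so far. Compound 1 `Nc1ncnc2c([C@@H]3O[C@H](CO)[C@@H](O)[C@H]3O)cnn12` gives in this assay only a limit of the assay, > 64000 nM. Compound 2 `Nc1nccn2c([C@@H]3O[C@H](CO)[C@@H](O)[C@H]3O)cnc12` likewise gives only a limit, > 64000 nM. Compound 3 `Nc1ncnn2c([C@@H]3O[C@H](CO)[C@@H](O)[C@H]3O)cc(-c3ccc(Cl)c(F)c3)c12` also reaches only a limit, > 64000 nM. So compound 3 stands exactly where the other two measured compounds stand, and the three values show no difference between them. The step now goes to compound 4 `Nc1ncnn2c([C@@H]3O[C@H](CO)[C@@H](O)[C@H]3O)cc(-c3ccc(Cl)cc3)c12`, which differs from compound 3 in a single place: hydrogen in place of fluoro on an aromatic carbon. Among the compounds with values here, no measured pair differs in only one place, so no step within this assay can be drawn from the data. Because the limit of > 64000 nM in this assay, at which 3 of the 3 values shown sit, holds every measured compound at the same limit, no step beyond the scatter is expected in either direction. The expected step, a number no higher from compound 3 to compound 4 (the limit leaves the size open), is therefore about none. Compound 4 is expected to give about 64000 nM, between 32000 nM and 128000 nM, most likely reported once more only as a limit.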

Compound 4, half-maximal cytotoxic concentration: 5000 nM
The estimate for compound 4 lay 13-fold (1.11 log units) above the measured number; measured number below the stated range.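

In this assay, replacing fluoro with hydrogen on the aromatic carbon ortho to the chloro group, which turns 4-chloro-3-fluorophenyl into 4-chlorophenyl, gives an at least 12-fold lower number from compound 3 to compound 4 (1.10 log units; beyond the scatter). Within the data shown here, this shows that a single atom at this position can separate a compound held at the assay's limit from one with a measurable cytotoxic concentration, something the earlier compounds, all level with one another, could not reveal. The full size of the step stays unknown, since one end of it is only a limit: the limit of > 64000 nM in this assay, at which 3 of the 4 values shown sit.

The compounds shown leave open whether fluorine itself is needed at this carbon, or whether a methoxy group or an amine there would also keep the number at the limit. They also leave open how a plain phenyl ring without the chloro group would behave.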